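Terminal chain hydroxy removed: estimate for compound 3

The compounds below may be only part of what the source reports. "The series", "measured", "known", "first", "only" and "open" are said of these compounds alone.

Two members of this series have numbers in a functional assay on cells (Lymphocyte, Homo sapiens) for inhibition, read by flow cytometry, using a membrane potential dye, with a stated time of 16 h, tested at 500 nM; a lower number here means a weaker effect, a higher number a stronger effect of the compound at the concentration tested. Compound 1 `CCCCCCCCCCCCCCCCc1nc(N2CCC2)c(C)c(C)c1O` gives 85% in this assay. Compound 2 `Cc1c(N(C)C)nc(CCCCCCCCCCO)c(O)c1C` gives 50% in this assay, which is the lowest of the two numbers, and its nearest neighbour is compound 1, whose number is higher by a margin beyond the scatter of repeated measurements.

Compound 3 `CCCCCCCCCCc1nc(N(C)C)c(C)c(C)c1O` has not yet been measured in this assay. Its difference from compound 2 is hydrogen in place of hydroxy on a saturated chain carbon, ten or more bonds along the chain from an aromatic carbon. The change is confined to the saturated chain; the shared core of compound 2 and compound 3 is unchanged.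

Among the compounds with values here, no step between two measured compounds isolates this change, so no direct precedent for its size exists in the set. Within the data shown here, the only other number at hand is that of compound 1, which carries a saturated chain without a hydroxy and gives 85% in this assay; on that basis the expected step is a number 20 percentage points higher from compound 2 to compound 3 (beyond the scatter), upward and beyond the scatter, but with wide uncertainty. Compound 3 is estimated at 70% in this assay, with a plausible range from 48% to 90%.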

Compound 3, a percentage reported as activity, at one concentration (the size of the read-out at that concentration, not a potency): 90%
Beside the measured number, compound 3's estimate is 20 percentage points below it; low and high end bracket the measured number.
By their numbers in this assay, from the lowest: compound 2; then compounds 1 and 3 (each within the scatter of the next).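

In this assay, within the data shown here, this change can now be read directly for the first time, and it gives a number 40 percentage points higher from compound 2 to compound 3 (beyond the scatter), a large step from a single edit on the saturated chain with the shared core unchanged. The far end of the chain is therefore not a silent site at the tested concentration, and within this pair the hydroxy compound is the one with the weaker effect. No available measurement bears on why the step has this size.

The compounds shown leave open whether the step is specific to hydroxy or whether other groups at the same chain end, such as an amine or a carboxylic acid, would also give a lower read-out than the unsubstituted chain. Among these compounds, it also remains open whether hydrogen in place of hydroxy gives a step of similar size on a longer chain or with a different group on the shared core, since this pair is the only one that isolates the change.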